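Hepatocyte stability across the N-alkyl series

The source may hold more compounds than are shown below. What is called first, only, known or untested is meant among the compounds shown, and "the series" means these compounds.

The shared core carries an acid-bearing cyclopropyl ketone on one side and a substituted nitrogen on the other. Compound 1 `COc1cc(N(CC2CC2)c2ccc(Cl)c(Cl)c2)cnc1C(=O)[C@H]1C[C@@H]1C(=O)O` gives 4.3 uL/min in an ADME assay on cells (Hepatocyte, Homo sapiens) for metabolic stability, read by LC-MS, with a stated time of 60 min, tested at 1 uM; on this read-out lower numbers stand for slow clearance and higher numbers for fast clearance. Compound 2 `COc1cc(N(CC2CC2)c2cccc(C(F)(F)F)c2)cnc1C(=O)[C@H]1C[C@@H]1C(=O)O` gives 2.3 uL/min in this assay, and compound 3 `COc1cc(N(CC(C)C)c2cccc(C(F)(F)F)c2)cnc1C(=O)[C@H]1C[C@@H]1C(=O)O` gives 2.9 uL/min. The step of a 1.9-fold lower number from compound 1 to compound 2 (0.27 log units; within the scatter) and the step of a 1.3-fold higher number from compound 2 to compound 3 (0.10 log units; within the scatter) are both small. Compound 3 stands second highest of the three numbers, its nearest neighbour being compound 2 and its furthest compound 1, with both gaps within the scatter.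

Compound 4 `CCCN(c1cccc(C(F)(F)F)c1)c1cnc(C(=O)[C@H]2C[C@@H]2C(=O)O)c(OC)c1` is not yet measured. It differs from compound 3 as follows: hydrogen in place of methyl on a saturated chain carbon bound to two saturated chain carbons. Going by the values given here, the only measured step at the same place, a 1.3-fold higher number from compound 2 to compound 3 (0.10 log units; within the scatter), stayed within the scatter, and no measured step shows a change beyond the scatter anywhere. A step of no change at the digits printed from compound 3 to compound 4 (within the scatter) is therefore expected, that is, none beyond the scatter. Compound 4 is estimated at 2.9 uL/min, within the range 1.4 uL/min to 6 uL/min in this assay.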

Compound 4, intrinsic clearance in a liver preparation (reported as CLH), per the amount of preparation that the assay uses: 7.2 uL/min
For compound 4 the middle estimate is 2.5-fold (0.39 log units) below the measured one; the measured number lies above the stated range.
By their numbers in this assay, from the lowest: compounds 2, 3, 1 and 4 (each within the scatter of the next, the first and the last beyond it).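

In this assay, the chain on the nitrogen now shows a change beyond the scatter, with removal of one methyl, isobutyl to propyl, giving a 2.5-fold higher number from compound 3 to compound 4 (0.39 log units; beyond the scatter) in this series. Ethyl in place of cyclopropyl on the saturated chain carbon gives a 3.1-fold higher number from compound 2 to compound 4 (0.50 log units; beyond the scatter), whereas isopropyl in place of cyclopropyl at that carbon gave a 1.3-fold higher number from compound 2 to compound 3 (0.10 log units; within the scatter), so the end of this chain matters here even though the earlier step suggested otherwise. Nothing available explains this difference.

Still open, from the compounds shown here alone, is whether a longer chain such as butyl, or a chain ending in an amine, would lie with propyl or with isobutyl. Also open, going by these compounds, is whether the same step would appear with 3,4-dichlorophenyl in place of 3-(trifluoromethyl)phenyl on the nitrogen.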